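Swapping the Aryl Amide: From Difluorophenyl to Ethynylphenyl

The source may report more compounds than this note shows. Statements on the series, on what has been measured and on what is new or still open speak of the compounds shown alone.

Compound 1 `Cc1ccc(S(=O)(=O)N[C@@H](CC(=O)NC(C)(C)C)C(=O)NCCNC(=O)c2cc(Cl)ccc2Cl)cc1` and compound 2 `Cc1ccc(S(=O)(=O)N[C@@H](CC(=O)NC(C)(C)C)C(=O)NCCNC(=O)c2ccc(F)c(F)c2)cc1` share one core and differ only in the aromatic ring attached to a carbonyl carbon. In an ADME assay on Karpas-1106P cells (Homo sapiens) for cytotoxicity (on this read-out higher numbers stand for an effect only at larger amounts of compound and lower numbers for an effect already at smaller amounts), compound 1 gives > 11100 nM, which is a limit of the assay rather than a number. In this assay compound 2 likewise gives > 11100 nM, again a limit. The step that the two limits leave unreadable from compound 1 to compound 2 therefore cannot be read, because of the limit of > 11100 nM in this assay, at which 2 of the 2 values shown sit.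

Compound 3 `C#Cc1cccc(C(=O)NCCNC(=O)[C@H](CC(=O)NC(C)(C)C)NS(=O)(=O)c2ccc(C)cc2)c1` is not yet measured. Its change from compound 2 is 3-ethynylphenyl in place of 3,4-difluorophenyl on a carbonyl carbon. Among the compounds with values here, the only measured step, a step that the two limits leave unreadable from compound 1 to compound 2, offers no guidance on direction or size, since both measured compounds sit at the same limit. The expectation is therefore that compound 3, like compound 2, shows no effect up to the limit in this assay. Compound 3 is estimated at 15000 nM, within a range from 5000 nM to 50000 nM, and most likely reported only as a limit. The step that the limit leaves unreadable from compound 2 to compound 3 is expected to be none beyond the scatter.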

Compound 3, half-maximal effective concentration: > 11100 nM
Compound 3: only a limit was reported; the forecaster's own chance of this, stated with the estimate: 85%; the middle value is on the limit's open side.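

In this assay, neither the step from compound 2 to compound 3 nor the step from compound 1 to compound 3 can be read, because all three compounds sit at the same limit: the limit of > 11100 nM in this assay, at which 3 of the 3 values shown sit.

The compounds shown leave open whether the 3-ethynylphenyl, 3,4-difluorophenyl and 2,5-dichlorophenyl groups differ at all in this assay, and which change to the shared core, if any, would yield a readable number.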